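The source may hold more compounds than are shown below. What is called first, only, known or untested is meant among the compounds shown, and "the series" means these compounds.

Of the compounds shown here, three sharing one core have been measured in an in vitro functional assay on cells for agonist activity at Bombesin receptor subtype-3 (Homo sapiens), read by luminescence and calcium flux; a higher number here means that more compound is needed for the effect, a lower number that less compound is needed. Compound 1, `CCCCc1cnc(CCc2ccc(-c3ccccc3C(=O)O)cc2)[nH]1`, gives 2710 nM. Compound 2, `O=C(O)c1ccccc1-c1ccc(CCc2ncc(CC3CCCCC3)[nH]2)cc1`, gives 41 nM. Compound 3, `COc1ccccc1Cc1cnc(CCc2ccc(-c3ccccc3C(=O)O)cc2)[nH]1`, gives 1720 nM, which places it second highest of the three: the step of a 1.6-fold lower number from compound 1 to compound 3 (0.20 log units; within the scatter) is within the scatter, while the step of a 42-fold higher number from compound 2 to compound 3 (1.62 log units; beyond the scatter) is large and beyond it. The step of a 66-fold lower number from compound 1 to compound 2 (1.82 log units; beyond the scatter) shows the same substituent position controlling most of the spread seen so far.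

Compound 4, `O=C(O)c1ccccc1-c1ccc(CCc2ncc(CCc3ccccc3)[nH]2)cc1`, is not yet measured. Its change from compound 3 is benzyl in place of 2-methoxyphenyl on a saturated chain carbon bound to an aromatic carbon. Among the compounds with values here, the steps that bear on it are the one from compound 1 to compound 3, where a propyl and a 2-methoxyphenyl gave the same result within the scatter, and the one from compound 2 to compound 3, where a cyclohexyl had given a much lower number. Within the data shown here, a benzyl at this position has no direct precedent here; it shares the saturated chain extension with the cyclohexylmethyl of compound 2 but carries an aromatic ring like compound 3. On that balance a modest step downward is expected, a 2.9-fold lower number from compound 3 to compound 4 (0.46 log units; beyond the scatter), with wide uncertainty. Compound 4 is therefore estimated at 600 nM, within a range from 100 nM to 4000 nM.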

Compound 4, half-maximal effective concentration: 1320 nM
Compound 4: middle estimate off by 2.2-fold (0.34 log units), on the low side; the range from low to high includes it.
By their numbers in this assay, from the lowest: compound 2; then compounds 4, 3 and 1 (each within the scatter of the next, the first and the last beyond it).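

The swap of 2-methoxyphenyl for benzyl gives a 1.3-fold lower number from compound 3 to compound 4 (0.11 log units; within the scatter) in this assay, so with a six-membered aromatic ring of carbon at this place, losing the methoxy oxygen and moving the ring one carbon further out makes no readable difference. The cyclohexyl stands apart more clearly now: benzyl in its place gives a 32-fold higher number from compound 2 to compound 4 (1.51 log units; beyond the scatter), a gap of the same order as a 42-fold higher number from compound 2 to compound 3 (1.62 log units; beyond the scatter), so among these four compounds the low number belongs to compound 2 alone, and neither aromatic group comes near it. Phenyl in place of ethyl gives only a 2.1-fold lower number from compound 1 to compound 4 (0.31 log units; beyond the scatter), so an aromatic ring at the end of the chain improves little on the plain butyl of compound 1, and no measurement shown says why the cyclohexyl behaves so differently.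

Still open is whether the low number needs exactly cyclohexyl, since the compounds shown do not tell how cyclopentyl or cycloheptyl would fare at this place. They also leave unanswered whether a piperidinyl ring, which brings an amine into the saturated ring, or a longer chain carrying the cyclohexyl would keep that number.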